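The source may report more compounds than this note shows. Statements on the series, on what has been measured and on what is new or still open speak of the compounds shown alone.

Measured in a functional assay on NB1 cells (Homo sapiens) for antiproliferative activity, with a stated time of 72 h; on this read-out higher numbers stand for weaker inhibition and lower numbers for stronger inhibition:
compound 1 `Cc1cc(C)cc(C(=O)N(CCC(=O)NCc2ccccc2)Cc2ccc(C(=O)NO)cc2)c1` gives 3870 nM
compound 2 `Cc1ccc(CNC(=O)CCN(Cc2ccc(C(=O)NO)cc2)C(=O)c2ccc(N(C)C)cc2)cc1` gives 700 nM
compound 3 `CN(C)c1ccc(C(=O)N(CCC(=O)NCc2ccc(Cl)cc2)Cc2ccc(C(=O)NO)cc2)cc1` gives 850 nM

Compound 3 sits level with compound 2 within the scatter, and its number is clearly lower than that of compound 1. Compound 4 `Cc1ccc(NC(=O)CCN(Cc2ccc(C(=O)NO)cc2)C(=O)c2ccc(N(C)C)cc2)cc1` comes next, with 4-methylphenyl in place of 4-chlorobenzyl on an amide-type nitrogen in short, 4-methylphenyl in place of 4-chlorobenzyl on an amide-type nitrogen. Going by the values given here, one measured step bears on this: chloro in place of methyl on an aromatic carbon gave a 1.2-fold higher number from compound 2 to compound 3 (0.08 log units; within the scatter), so that part of the change is expected to count for little. Among the compounds with values here, no measured step covers benzyl against phenyl here, which widens the range. In this assay no shift beyond the scatter is expected, the estimated move being a 1.1-fold lower number from compound 3 to compound 4 (0.03 log units; within the scatter) as a central guess. Compound 4 is estimated at 800 nM (300 nM to 2200 nM).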

Compound 4, half-maximal inhibitory concentration: 660 nM
Compound 4: middle estimate off by 1.2-fold (0.08 log units), on the high side; low and high end bracket the measured number.
By their numbers in this assay, from the lowest: compounds 4, 2 and 3 (each within the scatter of the next); then compound 1.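

Going by these compounds alone, on the amide-type nitrogen, 4-methylphenyl in place of 4-methylbenzyl gives a 1.1-fold lower number from compound 2 to compound 4 (0.03 log units; within the scatter) in this assay, the first reading of phenyl against benzyl here with the methyl kept. Against 4-chlorobenzyl the same group gives a 1.3-fold lower number from compound 3 to compound 4 (0.11 log units; within the scatter), so this position tolerates the shorter attachment among these compounds, and the two benzyl groups and 4-methylphenyl stay level. No measured evidence explains this flatness.

Open, going by these compounds, is whether 4-chlorophenyl also stays level. Also open, on these data alone, is whether this position tolerates 2-phenylethyl or a phenyl ring carrying a carboxylic acid or an amine.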